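Methoxy addition on the aryl ketone side of the chalcone series

The source may report more compounds than this note shows. Statements on the series, on what has been measured and on what is new or still open speak of the compounds shown alone.

Measured so far:
- compound 1, `COc1ccc(C(=O)/C=C/c2cc(-c3cc(OC)c(OC)c(OC)c3)n[nH]2)cc1OC`: 97%
- compound 2, `COc1cc(-c2cc(/C=C/C(=O)c3ccc(F)c(F)c3)[nH]n2)cc(OC)c1OC`: 100%

Both measured compounds were run in a functional assay on A498 cells (Homo sapiens) for cytotoxicity, read by sulforhodamine B assay, with a stated time of 48 h, tested at 0.01 uM; on this read-out lower numbers stand for a stronger effect and higher numbers for a weaker effect at the one concentration tested. At the single concentration used, compound 1 gives 97% and compound 2 gives 100%, and the two values sit within the scatter of each other, so neither can be ranked against the other; both stand where the read-out shows hardly any effect. Among the compounds with values here, the only step recorded so far is a number 3 percentage points higher from compound 1 to compound 2 (within the scatter), which replaced 3,4-dimethoxyphenyl on the carbonyl carbon by 3,4-difluorophenyl without moving the number beyond the scatter.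

Compound 3, `COc1cc(C(=O)/C=C/c2cc(-c3cc(OC)c(OC)c(OC)c3)n[nH]2)cc(OC)c1OC`, differs from compound 1 by methoxy in place of hydrogen on an aromatic carbon. Within the data shown here, no measured step touches this change directly; the one step available, a number 3 percentage points higher from compound 1 to compound 2 (within the scatter), altered the same aryl ketone side and left the read-out flat. On that basis the step from compound 1 to compound 3 is expected to be a number 1 percentage points higher from compound 1 to compound 3 (within the scatter), that is, none beyond the scatter. Compound 3 is therefore estimated at 98%, with a range from 88% to 105%.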

Compound 3, a percentage reported as activity, at one concentration (the size of the read-out at that concentration, not a potency): 95%
For compound 3 the middle estimate is 3 percentage points above the measured one, within the range that was stated.
By their numbers in this assay, from the lowest: compounds 3, 1 and 2 (each within the scatter of the next).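

Methoxy in place of hydrogen on an aromatic carbon of the aryl ketone ring, ortho to a methoxy group, meta to a methoxy group and meta to a large group, gives in this assay a number 2 percentage points lower from compound 1 to compound 3 (within the scatter), so adding a group at this position, rather than exchanging the existing ones as in a number 3 percentage points higher from compound 1 to compound 2 (within the scatter), also leaves the number within the scatter. At the one concentration tested, compound 3 at 95% still stands where the read-out shows hardly any effect, so this position shows no sensitivity to methoxy on this read-out, though a single concentration this close to no effect can hide differences that a fuller measurement might reveal. Nothing available on these compounds speaks to the reason for this result.

On these data alone, it remains open whether an amine or a carboxylic acid on this same aromatic carbon, or a longer chain such as ethoxy in place of the methoxy, would bring a step beyond the scatter. As far as these compounds go, it also remains open whether methoxy here would separate from hydrogen at a concentration where compound 1 and compound 3 show a clear effect.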